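Bombesin subtype-3 agonist series: alkyl versus aryl side groups

The source may hold more compounds than are shown below. What is called first, only, known or untested is meant among the compounds shown, and "the series" means these compounds.

Measured so far in an in vitro functional assay on cells for agonist activity at Bombesin receptor subtype-3 (Homo sapiens), read by luminescence and calcium flux; on this read-out lower numbers stand for an effect already at smaller amounts and higher numbers for an effect only at larger amounts of compound:
- compound 1 `CCCCc1cnc(CCCc2ccc(-c3ccccc3C(=O)O)cc2)[nH]1`: 5600 nM
- compound 2 `CCCCc1cnc(C(CCCC)Cc2ccc(-c3ccccc3C(=O)O)cc2)[nH]1`: 2660 nM
- compound 3 `O=C(O)c1ccccc1-c1ccc(CCc2ncc(Cc3ccccc3Cl)[nH]2)cc1`: 292 nM

Compound 3 stands lowest of the three numbers in this assay; the gap to compound 2 and the wider gap to compound 1 both lie well beyond the scatter, so compound 3 is the most potent of the measured set. Compounds 1 and 2 carry saturated alkyl groups where compound 3 carries a chloro-substituted aryl group, and both return higher numbers.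

Compound 4 `CC(C)(C)CCc1cnc(CCc2ccc(-c3ccccc3C(=O)O)cc2)[nH]1` has not yet been measured. It differs from compound 3 in one place: neopentyl in place of 2-chlorophenyl on a saturated chain carbon bound to an aromatic carbon. This change moves compound 4 toward the alkyl pattern of compounds 1 and 2.

Because compound 1 gives 5600 nM and compound 2 gives 2660 nM while compound 3 gives 292 nM, a step toward higher numbers beyond the scatter is expected for compound 4. The expected step is a 5.1-fold higher number from compound 3 to compound 4 (0.71 log units; beyond the scatter). For compound 4 the estimate in this assay is 1500 nM, within a range from 400 nM to 6000 nM.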

Compound 4, half-maximal effective concentration: 39 nM
Compound 4: the middle estimate sits 38-fold (1.59 log units) above what was measured; the measured number lies below the stated range.
By their numbers in this assay, from the lowest: compound 4; then compound 3; then compound 2; then compound 1.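

In this assay, within the data shown here, the change of 2-chlorophenyl to neopentyl, on a saturated chain carbon bound to an aromatic carbon, gives a 7.5-fold lower number from compound 3 to compound 4 (0.87 log units; beyond the scatter), the first step that alters one place only. At this position neither the aromatic ring nor the chlorine is needed for a low number, and the higher numbers of compounds 1 and 2 cannot be read as the result of a saturated side group alone, since each differs from compound 3 in more than one place. Nothing measured on these compounds accounts for the step.

Still open, going by these compounds, is whether a cyclohexyl or an unsubstituted phenyl at this position would fall nearer compound 3 or compound 4. Also open, on these data alone, is how a longer chain than 3,3-dimethylbutyl, or an amine at its end, would read.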